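The source may hold more compounds than are shown below. What is called first, only, known or untested is meant among the compounds shown, and "the series" means these compounds.

Working notes on the step from compound 2 to compound 4. In an ADME assay on microsomes (Mus musculus) for metabolic stability, read by LC-MS, using NADPH, with a stated time of 1 h, tested at 1 uM (on this read-out higher numbers stand for fast clearance and lower numbers for slow clearance), compound 1 `CC(=O)Nc1cccc(Cn2cc(-c3ccc4cn[nH]c4c3)ccc2=O)c1` gives 47 mL.min-1.g-1 and compound 3 `O=c1ccc(-c2ccc3cn[nH]c3c2)cn1Cc1cccc(C(F)(F)F)c1` gives 63 mL.min-1.g-1. In this assay compound 2 `Nc1n[nH]c2cc(-c3ccc(=O)n(Cc4cccc(Cl)c4)c3)ccc12` gives < 10 mL.min-1.g-1, which is a limit of the assay and not a number. Compound 2 therefore stands at the limit of < 10 mL.min-1.g-1 in this assay, at which 1 of the 3 values shown sits. Compounds 1 and 3 give numbers, and compound 2 gives only a limit.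

Compound 4 `Nc1n[nH]c2cc(-c3ccc(=O)n(Cc4ccccc4)c3)ccc12` keeps the core of compound 2, a core that compounds 1 and 3 do not share. The structural change is hydrogen in place of chloro on an aromatic carbon, which is hydrogen in place of chloro on an aromatic carbon, meta to a large group, or 3-chlorobenzyl to benzyl.

Among the measured compounds shown here, no measured step covers this exact change. The nearest evidence is a different exchange on an aromatic carbon, trifluoromethyl in place of acetamido, which gave a 1.3-fold higher number from compound 1 to compound 3 (0.13 log units; within the scatter). On that single step, no change beyond the scatter is expected in this assay, and compound 4 is expected to stay close to the limit, where it may also be reported only as a limit. The expected step is a number no lower from compound 2 to compound 4 (the limit leaves the size open). For compound 4 the estimated value is 10 mL.min-1.g-1, with an expected range from 6 mL.min-1.g-1 to 22 mL.min-1.g-1.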

Compound 4, intrinsic clearance in microsomes: < 10 mL.min-1.g-1
Compound 4 ended at the assay's limit; the forecaster's own chance of this, stated with the estimate: 55%; the middle value sits exactly at the limit.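

Compound 2 and compound 4 are both reported only as a limit in this assay, so no step can be read between them: the limit of < 10 mL.min-1.g-1 in this assay, at which 2 of the 4 values shown sit.

The compounds shown leave open whether 3-chlorobenzyl and benzyl differ at all in intrinsic clearance in microsomes on the core of compound 2.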